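The compounds below may be only part of what the source reports. "The series", "measured", "known", "first", "only" and "open" are said of these compounds alone.

In a functional assay on HUVEC cells (Homo sapiens) for inhibition (a higher number here means a weaker inhibitor, a lower number a stronger inhibitor), compound 1 `CN(c1ccc(NC(=N)Nc2ccccc2)cc1)c1ccnc(Nc2cccc(CS(C)(=O)=O)c2)n1` gives 596 nM, the higher of the two numbers available, while compound 2 `CCNC(=O)Nc1ccc(N(C)c2ccnc(Nc3ccc(CS(C)(=O)=O)cc3)n2)cc1` gives 27 nM, a lower number by a margin beyond the scatter. Compound 3 `CN(c1ccc(NC(=O)NC2CCCC2)cc1)c1ccnc(Nc2cccc(CS(C)(=O)=O)c2)n1` has yet to be measured. Its change from compound 1 is a group of 8 heavy atoms (6 carbon, 1 nitrogen, 1 oxygen; one five-membered non-aromatic ring of carbon only) in place of a group of 9 heavy atoms (7 carbon, 2 nitrogen; one six-membered aromatic ring of carbon only), on a nitrogen on an aromatic ring, and the group that enters is cyclopentylcarbamoyl, which contains a carbonyl. Compound 2, at 27 nM, also bears a carbonyl on a nitrogen on an aromatic ring, although its structure differs from compound 1 in more than one place. Going by the values given here, no measured pair isolates this change, so the expectation remains tentative. A fall beyond the scatter is expected, and the estimated change is an 8.5-fold lower number from compound 1 to compound 3 (0.93 log units; beyond the scatter). The estimated value for compound 3 is 70 nM, with an expected range of 15 nM to 300 nM.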

Compound 3, half-maximal inhibitory concentration: 1 nM
Compound 3: the middle estimate sits 70-fold (1.85 log units) above what was measured; measured number outside the range, below it.
By their numbers in this assay, from the lowest: compound 3; then compound 2; then compound 1.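

In this assay, exchanging the group on a nitrogen on an aromatic ring for cyclopentylcarbamoyl gives a 600-fold lower number from compound 1 to compound 3 (2.78 log units; beyond the scatter), a large step. Compound 1 and compound 3 are the first pair shown that differ in this one place, so the result shows that the number in this assay can depend strongly on the group carried there, which compound 2, differing from compound 1 in more than one place, could not show. No measurement among the data bears on the reason for the size of this step.

The change replaces the whole group at once, so the compounds shown leave open whether the carbonyl or the five-membered ring accounts for the step. On these data alone, how phenylcarbamoyl, which pairs the carbonyl with a six-membered aromatic ring, would stand at this place also remains open.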